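Swapping a Naphthyl for a Thiophene on the Urea Nitrogen

The source may report more compounds than this note shows. Statements on the series, on what has been measured and on what is new or still open speak of the compounds shown alone.

Three ureas share one core and differ only in the ring on one urea nitrogen. In an assay on isolated protein for inhibition of proto-oncogene tyrosine-protein kinase receptor Ret variant V804L (Homo sapiens), read by 33P incorporation, with stated times of 15 min and 40 min (a higher number here means a weaker inhibitor, a lower number a stronger inhibitor), compound 1 `Cc1ccc(F)c(NC(=O)Nc2ccc(Nc3ncnc4c3OCCN4)cc2)c1` gives 7000 nM. Compound 2 `O=C(Nc1ccc(Nc2ncnc3c2OCCN3)cc1)Nc1cc(Cl)cc(Cl)c1` gives 4480 nM in this assay. As far as these compounds go, for compound 3 `O=C(Nc1ccc(Nc2ncnc3c2OCCN3)cc1)Nc1cccc2ccccc12` the assay reports only a limit, > 10000 nM, so its exact value is unknown (the limit of > 10000 nM in this assay, at which 1 of the 3 values shown sits). The measured steps of a 1.6-fold lower number from compound 1 to compound 2 (0.19 log units; within the scatter), an at least 1.4-fold higher number from compound 1 to compound 3 (0.15 log units; that floor lies within the scatter) and an at least 2.2-fold higher number from compound 2 to compound 3 (0.34 log units; beyond the scatter) show that changing this ring has moved the numbers little, with the naphthalen-1-yl ring sitting at or beyond the edge. Compound 4 `O=C(Nc1ccc(Nc2ncnc3c2OCCN3)cc1)Nc1cccs1` carries the change (thiophen-2-yl in place of naphthalen-1-yl on an amide-type nitrogen). Within the data shown here, no measured step includes a thiophene, so the step from compound 3 is expected to be an at least 1.4-fold lower number from compound 3 to compound 4 (0.15 log units; that floor lies within the scatter), back toward the two measured values. Compound 4 is estimated at 7000 nM, within 2000 nM to 25000 nM.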

Compound 4, half-maximal inhibitory concentration: > 10000 nM
Compound 4: a limit, no number; the forecaster's own chance of this, stated with the estimate: 40%; middle value at least 1.4-fold (0.15 log units) from the limit.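

Thiophen-2-yl, a single five-membered ring, leaves compound 4 at a limit of the assay rather than a number, as the two-ring naphthalen-1-yl did for compound 3, so neither ring size gives a measured value here: the limit of > 10000 nM in this assay, at which 2 of the 4 values shown sit.

Thiophen-2-yl in place of 3,5-dichlorophenyl gives an at least 2.2-fold higher number from compound 2 to compound 4 (0.34 log units; beyond the scatter), and in place of 2-fluoro-5-methylphenyl it gives an at least 1.4-fold higher number from compound 1 to compound 4 (0.15 log units; that floor lies within the scatter). The step between the two limits cannot be read.

Still open, as far as these compounds go, is whether a pyridine ring or a cyclohexyl group on this nitrogen would give a measurable number in this assay.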